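This account rests on a few compounds, and the source may have more. Where it says the series, first, only, none or still open, it means among the compounds named here.

Compound 1 `O=c1cc(-c2ccccc2)oc2ccc(OC/C(=N/O)c3ccccc3)cc12` gives 700000 nM in a functional assay on SK-HEP1 cells (Homo sapiens) for antiproliferative activity; on this read-out lower numbers stand for stronger inhibition of growth and higher numbers for weaker inhibition of growth. Compound 2 `O=c1cc(-c2ccccc2)oc2ccc(OC/C(=N/O)c3ccc(F)cc3)cc12` gives 2800000 nM in this assay. Compound 3 `CO/N=C(/COc1c(-c2ccccc2)oc2ccccc2c1=O)c1ccccc1` gives 7110000 nM in this assay.

Compound 1 and compound 2 share one core and differ in a single place: fluoro in place of hydrogen on an aromatic carbon. This change brought a 4.0-fold higher number from compound 1 to compound 2 (0.60 log units; beyond the scatter). Compound 3 is built on a different core, and the difference between the two cores is not broken down here; its number stands highest of the three, and compound 1 gives the lowest of the three.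

Compound 4 `CO/N=C(/COc1c(-c2ccccc2)oc2ccccc2c1=O)c1ccc(F)cc1` has not yet been measured. It stands to compound 3 as compound 2 stands to compound 1: fluoro in place of hydrogen on an aromatic carbon. The place lines of the two changes read the same, so this is the same change, seen before once among these compounds, where it weakened growth inhibition by a modest step.

Going by the values given here, on this basis compound 4 is expected to show a step of about a 2.8-fold higher number from compound 3 to compound 4 (0.45 log units; beyond the scatter) in this assay, beside the measured step from compound 1 to compound 2, because the single precedent a 4.0-fold higher number from compound 1 to compound 2 (0.60 log units; beyond the scatter) moved the number upward. Among the compounds with values here, the expectation rests on one pair only, and on a core that differs from the one that gave the precedent, so it carries a wide range. For compound 4 the estimated value is 20000000 nM, expected to lie between 7000000 nM and 60000000 nM.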

Compound 4, concentration for 50% growth inhibition: 13000000 nM
Estimate against measurement, compound 4: 1.5-fold (0.19 log units) above; the range from low to high includes it.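

In this assay, going from phenyl to 4-fluorophenyl on the core of compound 3 gave a 1.8-fold higher number from compound 3 to compound 4 (0.26 log units; within the scatter), so on this core the change cannot be told apart from the scatter of repeated measurements. Set beside the same change on the core of compound 1, this step shows no difference that the data can resolve: the same change on two cores in this assay, a 4.0-fold higher number (0.60 log units; beyond the scatter) from compound 1 to compound 2 and a 1.8-fold higher number (0.26 log units; within the scatter) from compound 3 to compound 4, 2.2-fold (0.34 log units) apart, within the scatter of two such steps

Going by these compounds alone, the two cores are thus compatible with a single shared step for this change, but this does not show that the change carries over unaltered or that it weakens growth inhibition on every core: there is one pair per core, only the step on the core of compound 1 lies beyond the scatter, and the difference between the cores is not broken down.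

The compounds shown leave open whether another group in the same place, such as chloro, trifluoromethyl, methoxy or an amine, would follow fluoro on either core. They also leave open whether a third core would give a step of similar size, and which of the features separating the two cores sets the gap in their numbers.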